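From ethyl to thiophen-2-yl on the oxygen

The compounds below may be only part of what the source reports. "The series", "measured", "known", "first", "only" and "open" are said of these compounds alone.

Of the compounds shown here, three have numbers so far in a functional assay on HeLa cells (Homo sapiens) for cytotoxicity; on this read-out lower numbers stand for stronger inhibition and higher numbers for weaker inhibition. Compound 1 `O=C1C=CC(=O)c2cc(OCc3ccccc3)ccc21` gives 16800 nM. Compound 2 `Cc1ccc(S(=O)(=O)OC2=CC(=O)c3ccccc3C2=O)cc1` gives 12200 nM. Compound 3 `CCOc1ccc2c(c1)C(=O)C=CC2=O` gives 25100 nM. This puts compound 3 at the upper end of the small set: it lies within the scatter of compound 1, while the number of compound 2 lies lower, beyond the scatter.

Compound 4 `O=C1C=CC(=O)c2cc(Oc3cccs3)ccc21` is still unmeasured. Its difference from compound 3 is thiophen-2-yl in place of ethyl on an oxygen on an aromatic ring. Going by the values given here, only one measured step bears on this part of the structure: a 1.5-fold higher number from compound 1 to compound 3 (0.17 log units; within the scatter). It stays within the scatter, so swapping methyl and phenyl on the saturated chain carbon moved the number little. Among the compounds with values here, no measured compound has an aromatic ring directly on that oxygen, so this guide is weak. Within the data shown here, compound 2 differs from compound 3 in more than one place and offers no step.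

No shift beyond the scatter is therefore expected in this assay. The expected change is a 1.4-fold lower number from compound 3 to compound 4 (0.14 log units; within the scatter). Compound 4 is estimated at 18000 nM, with an expected range from 7000 nM to 40000 nM.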

Compound 4, half-maximal inhibitory concentration: 8860 nM
Compound 4: the middle estimate sits 2.0-fold (0.31 log units) above what was measured, within the range that was stated.
By their numbers in this assay, from the lowest: compounds 4, 2, 1 and 3 (each within the scatter of the next, the first and the last beyond it).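

In this assay, going by these compounds alone, thiophen-2-yl in place of ethyl on an oxygen on an aromatic ring gives a 2.8-fold lower number from compound 3 to compound 4 (0.45 log units; beyond the scatter) and is the only step at this position that lies beyond the scatter. Within the data shown here, the one earlier step here, a 1.5-fold higher number from compound 1 to compound 3 (0.17 log units; within the scatter), exchanged two groups joined to the oxygen through a saturated carbon and stayed within the scatter, so it gave no sign that this position could shift the number; the new step shows that it can, and that an aromatic ring bound directly to the oxygen is accepted with a lower number than ethyl gives. This rests on a single modest step, and no measurement on hand gives a reason for it.

Open, on these data alone, is whether the shift belongs to thiophen-2-yl itself or would also appear with phenyl or furan-2-yl directly on the oxygen. Also open, as far as these compounds go, is how a group carrying an amine or a carboxylic acid, or a longer chain such as butyl, would read at the same position in this assay.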